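The compounds below may be only part of what the source reports. "The series", "measured", "known", "first", "only" and "open" are said of these compounds alone.

Compound 1 `c1ccc(-c2ccc3c(NCCCNCc4ccco4)ccnc3c2)cc1` was tested in an ADME assay on HepG2 cells (Homo sapiens) for cytotoxicity, read by luminescence, CellTiter-Glo and ATP content, with a stated time of 72 h (a lower number here means that less compound is needed, a higher number that more compound is needed for the effect), where compound 1 gives 5920 nM. That is the highest of the three numbers, though the gaps to the others are within the scatter: compound 2 `COc1cccc(CNCCCNc2ccnc3cc(Cc4ccccc4)ccc23)c1O` gives 5720 nM and compound 3 `COc1cccc(CNCCCNc2ccnc3cc(CCC(C)C)ccc23)c1O` gives 5390 nM. Within the data shown here, the one measured step, a 1.1-fold lower number from compound 2 to compound 3 (0.03 log units; within the scatter), put isobutyl in place of phenyl on a saturated chain carbon bound to an aromatic carbon and stayed within the scatter. Compound 4 `Fc1ccc(Cc2ccc3c(NCCCNCc4ccco4)ccnc3c2)c(Cl)c1` differs from compound 1 by 2-chloro-4-fluorobenzyl in place of phenyl on an aromatic carbon. Among the measured compounds shown here, no measured step covers this change, and the only step available was flat, so a step in this assay no larger than the scatter is expected, in no clear direction. Compound 4 is therefore estimated at 5500 nM, in the range 2200 nM to 14000 nM, meaning an expected 1.1-fold lower number from compound 1 to compound 4 (0.03 log units; within the scatter).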

Compound 4, half-maximal effective concentration: 5730 nM
Estimate against measurement, compound 4: 1.0-fold (0.02 log units) below, and the stated range covers the measured number.
By their numbers in this assay, from the lowest: compounds 3, 2, 4 and 1 (each within the scatter of the next).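

In this assay, the aromatic carbon that carries phenyl in compound 1 also takes 2-chloro-4-fluorobenzyl, a group with more heavy atoms, and the result is a 1.0-fold lower number from compound 1 to compound 4 (0.01 log units; within the scatter). The earlier step changed a group on a saturated chain carbon, whereas this one replaces the group on the aromatic carbon itself, and it also stays within the scatter. Nothing measured here explains this flat result.

Going by these compounds, whether an amine or a carboxylic acid on this aromatic carbon would move the number beyond the scatter remains open.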